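Bromo in place of trifluoromethyl: expected read-out for compound 3

A few compounds are considered here, and "the series" means these few. Any claim that something is new, unique, unknown or untested is made for them only; others in the source may bear on it.

Of the compounds shown here, two have so far been measured in a functional assay on NCI-H1581 cells (Homo sapiens) for inhibition, read by MTT assay, with a stated time of 48 h, tested at 10 uM; a higher number here means more inhibition at the concentration tested (going by the name of the read-out), a lower number less inhibition. Compound 1 `COc1cc(NC(=O)Nc2cc(Nc3ccc(C(C)(C)C)cc3)ncn2)cc(OC)c1` gives 38.7%. Compound 2 `COc1cc(NC(=O)Nc2cc(Nc3cc(C(F)(F)F)ccc3OC)ncn2)cc(OC)c1` gives 67.1%. On these two numbers compound 2 stands highest; its nearest neighbour is compound 1, whose number lies lower by a gap beyond the usual scatter. For the measured compounds named here, no pair of measured compounds differs in a single place, so the effect of any one substituent change has not been isolated directly.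

Compound 3 `COc1cc(NC(=O)Nc2cc(Nc3cc(Br)ccc3OC)ncn2)cc(OC)c1` is the next compound to be measured in this assay. It differs from compound 2 as follows: bromo in place of trifluoromethyl on an aromatic carbon. Both the leaving and the entering group carry no hydrogen-bond donors or acceptors and no net charge; one heavy atom enters where four leave. Going by the values given here, with no measured single-point step available, the step from compound 2 to compound 3 is expected to be small, most likely a modest drop or none beyond the scatter, a number 7.1 percentage points lower from compound 2 to compound 3 (within the scatter). Compound 3 is accordingly estimated at 60%, with a range from 40% to 78%.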

Compound 3, a percentage reported as inhibition, at one concentration (the size of the read-out at that concentration, not a potency): 23.1%
Estimate against measurement, compound 3: 36.9 percentage points above; measured number outside the range, below it.
By their numbers in this assay, from the lowest: compound 3; then compound 1; then compound 2.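

In this assay, for the compounds shown here, the first single-place step at this aromatic carbon, para to a methoxy group, is a number 44 percentage points lower from compound 2 to compound 3 (beyond the scatter) and shows that the read-out is strongly sensitive to the exchange of trifluoromethyl for bromo, even though neither group carries hydrogen-bond donors, hydrogen-bond acceptors or a net charge. The second step, a number 15.6 percentage points lower from compound 1 to compound 3 (beyond the scatter) with 5-bromo-2-methoxyphenyl in place of 4-(tert-butyl)phenyl on the nitrogen, shows that the methoxy-bearing aryl group does not keep the read-out high when bromo occupies this carbon, so among these three compounds the top number goes with the trifluoromethyl-bearing compound 2 alone. Going by these compounds alone, nothing measured so far accounts for the size of either step.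

The compounds shown leave open how chloro, nitrile or a carboxylic acid on this same carbon would read, and therefore whether trifluoromethyl stands out or bromo falls short. What the methoxy group itself contributes also remains open, as no pair shown changes it alone, and readings at a single concentration give no potency for any of the three compounds.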